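The compounds below may be only part of what the source reports. "The series", "measured", "known", "first", "only" and "open" are said of these compounds alone.

In an assay on SH-SY5Y cells for inhibition of Voltage-dependent N-type calcium channel subunit alpha-1B (Homo sapiens), read by FLIPR and calcium flux, with stated times of 600 s and 300 s, in the presence of a further agent that is not named here (on this read-out higher numbers stand for weaker inhibition and lower numbers for stronger inhibition), compound 1, `CN(Cc1ccc(OCCCNC(=N)N)cc1)c1nc2ccc(Oc3ccc(C(F)(F)F)cc3)cc2s1`, gives 185000 nM. Compound 2, `CN(Cc1ccc(OCCCN)cc1)c1nc2ccc(Oc3ccc(C(F)(F)F)cc3)cc2s1`, differs from compound 1 by a hydrogen atom in place of a group of 3 heavy atoms (1 carbon, 2 nitrogen; no ring), on an amine nitrogen, and in this assay compound 2 gives 283000 nM, so that the step is a 1.5-fold higher number from compound 1 to compound 2 (0.18 log units; within the scatter). Compound 3, `CN(Cc1ccc(OCCCNC(=N)N)cc1)c1nc2ccc(Oc3cccc(C(F)(F)F)c3)cc2s1`, carries the same guanidine-bearing side chain as compound 1 but a different aryl ether; the two cores differ by 3-(trifluoromethyl)phenyl in place of 4-(trifluoromethyl)phenyl on an oxygen on an aromatic ring. In this assay compound 3 gives 202000 nM, and the step is a 1.1-fold higher number from compound 1 to compound 3 (0.04 log units; within the scatter). Among the compounds with values here, all three measured numbers thus sit close together at the weak end of the read-out, with no step among them that the scatter would not cover.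

Compound 4, `CN(Cc1ccc(OCCCN)cc1)c1nc2ccc(Oc3cccc(C(F)(F)F)c3)cc2s1`, has not yet been measured. It stands to compound 3 as compound 2 stands to compound 1: the difference is a hydrogen atom in place of a group of 3 heavy atoms (1 carbon, 2 nitrogen; no ring), on an amine nitrogen, and the place of the change is the same word for word, so this is the same change made on the core of compound 3 rather than on the core of compound 1. Because the earlier example of this change gave a 1.5-fold higher number from compound 1 to compound 2 (0.18 log units; within the scatter), a step of about the same size is expected here, and the author estimates a 1.5-fold higher number from compound 3 to compound 4 (0.17 log units; within the scatter) from compound 3 to compound 4. Since the core change itself gave only a 1.1-fold higher number from compound 1 to compound 3 (0.04 log units; within the scatter), nothing in the data suggests that the second core would shift the outcome. Compound 4 is therefore expected to give roughly 300000 nM in this assay, most likely between 150000 nM and 600000 nM.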

Compound 4, half-maximal inhibitory concentration: 77000 nM
For compound 4 the middle estimate is 3.9-fold (0.59 log units) above the measured one; the measured number lies below the stated range.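

In this assay, the same change on the core of compound 3 gave a 2.6-fold lower number from compound 3 to compound 4 (0.42 log units; beyond the scatter), so the small step seen on the core of compound 1 did not carry over to this second core: the same change on two cores in this assay, a 1.5-fold higher number (0.18 log units; within the scatter) from compound 1 to compound 2 and a 2.6-fold lower number (0.42 log units; beyond the scatter) from compound 3 to compound 4, 4.0-fold (0.60 log units) apart, beyond the scatter of two such steps Seen from the other side of the same four compounds, 3-(trifluoromethyl)phenyl in place of 4-(trifluoromethyl)phenyl gave a 3.7-fold lower number from compound 2 to compound 4 (0.57 log units; beyond the scatter), whereas this swap had left the guanidine pair within the scatter: the same change on two cores in this assay, a 1.1-fold higher number (0.04 log units; within the scatter) from compound 1 to compound 3 and a 3.7-fold lower number (0.57 log units; beyond the scatter) from compound 2 to compound 4, 4.0-fold (0.60 log units) apart, beyond the scatter of two such steps This shows that, in this set, the outcome of either change depends on which form of the other part is present, so a step measured on one core cannot simply be transferred to the other; it rests on a single set of four compounds, however, and shows neither why the steps differ nor how the change would behave on any further core.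

The compounds shown leave open whether the same dependence appears with other aryl ethers, such as a chlorophenyl or methoxyphenyl group in place of the trifluoromethylphenyl group. They also leave open what a tertiary amine, an amide or a longer chain would do in place of the primary amine or the guanidine on each core.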